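The source may hold more compounds than are shown below. What is called first, only, known or untested is meant among the compounds shown, and "the series" means these compounds.

In an assay on brain for displacement of a labelled ligand from Adrenergic receptor alpha-1 (Rattus norvegicus) (a lower number here means a stronger inhibitor, a higher number a weaker inhibitor), the three measured compounds read as follows:

compound 1 `CCCCOCCOC1CCN(c2nc(N)c3cc(OC)c(OC)cc3n2)CC1`: 1.03 nM
compound 2 `COc1cc2nc(N3CCC(OCCOC(C)C)CC3)nc(N)c2cc1OC`: 0.67 nM
compound 3 `CCOC(COC1CCN(c2nc(N)c3cc(OC)c(OC)cc3n2)CC1)c1ccccc1`: 0.52 nM

Compound 3 holds the lowest of the three numbers in this assay, but its gaps to compound 2 and to compound 1 both lie within the scatter, so no order among the three can be claimed. Compound 4 `COc1cc2nc(N3CCC(OCC(C)(O)c4ccccc4)CC3)nc(N)c2cc1OC` differs from compound 3 in one place: 1-hydroxy-1-phenylethyl in place of ethoxy(phenyl)methyl on a saturated chain carbon bound to an oxygen on a saturated carbon. For the measured compounds named here, three measured steps touch the same region of the molecule, the chain hanging from the oxygen on the saturated carbon: a 2.0-fold lower number from compound 1 to compound 3 (0.30 log units; within the scatter), a 1.3-fold lower number from compound 2 to compound 3 (0.11 log units; within the scatter) and a 1.5-fold lower number from compound 1 to compound 2 (0.19 log units; within the scatter). Every one of them stayed within the scatter, whether the chain gained a phenyl, lost carbons or changed its branching. On that basis no step beyond the scatter is expected in this assay for the change from compound 3 to compound 4; the expected step is a 1.3-fold higher number from compound 3 to compound 4 (0.10 log units; within the scatter). Compound 4 is therefore estimated at 0.65 nM, with a range from 0.25 nM to 1.7 nM.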

Compound 4, inhibition constant: 0.62 nM
Compound 4: middle estimate off by 1.0-fold (0.02 log units), on the high side, within the range that was stated.
By their numbers in this assay, from the lowest: compounds 3, 4, 2 and 1 (each within the scatter of the next).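

In this assay, 1-hydroxy-1-phenylethyl in place of ethoxy(phenyl)methyl puts a hydrogen-bond donor into this chain, which none of the earlier chains carried, and the step stays within the scatter (a 1.2-fold higher number from compound 3 to compound 4 (0.08 log units; within the scatter)). Against the two chains without a phenyl the picture is the same (a 1.1-fold lower number from compound 2 to compound 4 (0.03 log units; within the scatter); a 1.7-fold lower number from compound 1 to compound 4 (0.22 log units; within the scatter)), so at this place, on a saturated chain carbon bound to an oxygen on a saturated carbon, a hydroxy-bearing group and the ether chains give readings that cannot be told apart. Nothing measured here explains this result.

Going by these compounds, whether an amine, a carboxylic acid or a much longer chain at this place would produce a step beyond the scatter remains open. All four compounds sit within the scatter of one another in this assay, so none of them shows how far this position can be changed before the number moves.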